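Compound 3: 1H-pyrazol-1-yl in place of 1,3-oxazol-2-yl

A few compounds are considered here, and "the series" means these few. Any claim that something is new, unique, unknown or untested is made for them only; others in the source may bear on it.

Of the compounds shown here, two have been read in an in vitro ADME assay on microsomes from liver (Rattus norvegicus) for metabolic stability; on this read-out lower numbers stand for slow clearance and higher numbers for fast clearance. Compound 1 (`Cc1ccc(Cn2c(=O)[nH]c3c(N)nc(-c4ncco4)cc32)cn1`) gives < 8.5 mL.min-1.g-1, which is a limit of the assay and not a number. Compound 2 (`CN1CCN(c2ccc(Cn3c(=O)[nH]c4c(N)nc(C(F)(F)F)cc43)cn2)CC1`) gives 46 mL.min-1.g-1. Compound 2 differs from compound 1 in more than one place, so the two values say nothing about a single change.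

The next step leads to compound 3 (`Cc1ccc(Cn2c(=O)[nH]c3c(N)nc(-n4cccn4)cc32)cn1`). On an aromatic carbon next to the ring nitrogen, 1H-pyrazol-1-yl stands in place of 1,3-oxazol-2-yl, and the rest of compound 1 is kept (1H-pyrazol-1-yl in place of 1,3-oxazol-2-yl on an aromatic carbon). Within the data shown here, both groups are five-membered aromatic rings with 2 hetero atoms, and no measured step covers this exchange. A small change is expected in this assay, and any shift is expected to be upward since compound 1 sits at the limit of < 8.5 mL.min-1.g-1. The expected size is an at least 1.1-fold higher number from compound 1 to compound 3 (0.07 log units; that floor lies within the scatter). Compound 3 is estimated at 10 mL.min-1.g-1, with an expected range from 5 mL.min-1.g-1 to 25 mL.min-1.g-1.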

Compound 3, intrinsic clearance in microsomes: < 8.5 mL.min-1.g-1
Compound 3: a limit, no number; the forecaster's own chance of this, stated with the estimate: 45%; middle value at least 1.1-fold (0.07 log units) away from the limit.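

Among these compounds, compound 1 and compound 3 both read as limits of the assay and not as numbers, so no step between them can be read in this assay: the limit of < 8.5 mL.min-1.g-1 in this assay, at which 2 of the 3 values shown sit. The compounds shown leave open whether 1H-pyrazol-1-yl in place of 1,3-oxazol-2-yl changes intrinsic clearance at all, and in which direction any change would run.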